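Swapping cyclohexyl for benzyl on the ring nitrogen

The source may report more compounds than this note shows. Statements on the series, on what has been measured and on what is new or still open speak of the compounds shown alone.

Measured compounds:
Compound 1, `c1ccc2c(-c3cn4ccnc4c(-c4ccc5ncn(C6CCCCC6)c5c4)n3)cccc2c1`: 16.7%
Compound 2, `Fc1ccc(-c2cn3ccnc3c(-c3ccc4ncn(C5CCCCC5)c4c3)n2)cc1`: 31%
Compound 3, `c1csc(-c2cn3ccnc3c(-c3ccc4ncn(C5CCCCC5)c4c3)n2)c1`: 24.8%

In a functional assay on UACC-62 cells (Homo sapiens) for inhibition, read by sulforhodamine B assay, with a stated time of 48 h, tested at 10 uM (on this read-out higher numbers stand for more inhibition at the one concentration tested (going by the name of the read-out) and lower numbers for less inhibition), compound 1 gives 16.7%, the smallest of the three numbers. Its gap to compound 2 is a number 14.3 percentage points higher from compound 1 to compound 2 (beyond the scatter), while its gap to compound 3 is a number 8.1 percentage points higher from compound 1 to compound 3 (within the scatter), so only compound 2 stands clearly apart from it. Compound 4, `c1ccc(Cn2cnc3ccc(-c4nc(-c5cccc6ccccc56)cn5ccnc45)cc32)cc1`, has not yet been measured. It differs from compound 1 in one place: benzyl in place of cyclohexyl on an aromatic nitrogen. For the measured compounds named here, none of the measured steps touches this position; all three of them exchange the aryl group on an aromatic carbon, and of those the largest, a number 14.3 percentage points higher from compound 1 to compound 2 (beyond the scatter), is modest, with a number 6.2 percentage points lower from compound 2 to compound 3 (within the scatter) and a number 8.1 percentage points higher from compound 1 to compound 3 (within the scatter) both inside the scatter. Nothing in these data therefore speaks for a substantial move in this assay when cyclohexyl gives way to benzyl. The expected step is a number 2.3 percentage points higher from compound 1 to compound 4 (within the scatter), that is, no change beyond the scatter. Compound 4 is estimated to give 19%, with a range from 5% to 38%.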

Compound 4, a percentage reported as inhibition, at one concentration (the size of the read-out at that concentration, not a potency): 12.9%
Compound 4: the middle estimate sits 6.1 percentage points above what was measured; the measured number falls inside the stated range.
By their numbers in this assay, from the lowest: compounds 4, 1, 3 and 2 (each within the scatter of the next, the first and the last beyond it).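

In this assay, for the compounds shown here, the first reading at the aromatic nitrogen, which the earlier steps left untouched, is a number 3.8 percentage points lower from compound 1 to compound 4 (within the scatter). With naphthalen-1-yl held in place, a six-membered non-aromatic ring of carbon only on that nitrogen can thus give way to benzyl, with its aromatic ring, without a change beyond the scatter. Nothing available bears on why the two groups read alike.

On these data alone, whether benzyl would read the same alongside 4-fluorophenyl or thiophen-2-yl, the two aryl groups that sit with cyclohexyl in compound 2 and compound 3, remains open. Also open, as far as these compounds go, is whether a different kind of group on the ring nitrogen, such as a longer chain ending in an amine or a carboxylic acid, would shift the number.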